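The source may report more compounds than this note shows. Statements on the series, on what has been measured and on what is new or still open speak of the compounds shown alone.

Values in a functional assay on DU-145 cells (Homo sapiens) for antiproliferative activity, read by WST assay, with a stated time of 3 days; on this read-out lower numbers stand for stronger inhibition and higher numbers for weaker inhibition:
- Compound 1 `COc1cc(-c2oc3ccccc3c(=O)c2OC(C)C)cc(OC)c1OC`: > 50000 nM, a limit of the assay
- Compound 2 `CCCN(CCC)CCCCOc1c(-c2cc(OC)c(OC)c(OC)c2)oc2ccccc2c1=O`: 35800 nM
- Compound 3 `CCCCN(CCCC)CCCOc1c(-c2cc(OC)c(OC)c(OC)c2)oc2ccccc2c1=O`: not yet measured

Among the measured compounds shown here, compound 2 at 35800 nM holds the only actual number so far, so it has no numerical neighbour to rank against. The change to compound 3 is dibutylamino in place of (dipropylamino)methyl on a saturated chain carbon, three bonds along the chain from an oxygen on an aromatic ring, three bonds along the chain from an oxygen on an aromatic ring. For the measured compounds named here, the sole measured step, an at least 1.3-fold lower number from compound 1 to compound 2 (0.14 log units; that floor lies within the scatter), involves a different change and gives no shift beyond the scatter, so none is expected in this assay here. The expected step is a 1.2-fold lower number from compound 2 to compound 3 (0.08 log units; within the scatter). Compound 3 is estimated at 30000 nM, with an expected range of 12000 nM to 50000 nM.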

Compound 3, half-maximal inhibitory concentration: 15700 nM
Compound 3: middle estimate off by 1.9-fold (0.28 log units), on the high side; the range from low to high includes it.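

In this assay, dibutylamino in place of (dipropylamino)methyl on this saturated chain carbon gives a 2.3-fold lower number from compound 2 to compound 3 (0.36 log units; beyond the scatter), the first shift beyond the scatter between two actual numbers. 3-(dibutylamino)propyl in place of isopropyl gives an at least 3.1-fold lower number from compound 1 to compound 3 (0.50 log units; beyond the scatter). That step is only a floor, as the value of compound 1 is a limit of the assay: the limit of > 50000 nM in this assay, at which 1 of the 3 values shown sits.

The change shortens the chain carrying the nitrogen and lengthens the groups on it at once, so the two stay unseparated. Going by these compounds, whether a 4-(dibutylamino)butyl chain or a piperidine on the same chain lowers the number further remains open.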